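Fluoro in Place of Nitro: Expected Cytotoxicity of Compound 4

This account rests on a few compounds, and the source may have more. Where it says the series, first, only, none or still open, it means among the compounds named here.

Measured compounds:
compound 1 `Cc1ccc2[nH]c(=O)c(-c3nc4cc([N+](=O)[O-])ccc4[nH]3)cc2c1` gives > 100000 nM
compound 2 `O=c1[nH]c2ccccc2cc1-c1nc2cc([N+](=O)[O-])ccc2[nH]1` gives > 100000 nM
compound 3 `Cc1ccc2[nH]c(=O)c(-c3nc4cc(C)c(C)cc4[nH]3)cc2c1` gives > 100000 nM

In an ADME assay on L02 cells (Homo sapiens) for cytotoxicity, read by MTT assay, with a stated time of 48 h (a lower number here means a stronger inhibitor, a higher number a weaker inhibitor), compound 1 gives > 100000 nM, which is a limit of the assay and not a number. Compound 2 gives > 100000 nM, likewise a limit. Compound 3 gives > 100000 nM, again a limit. Compound 1 therefore stands at the limit of > 100000 nM in this assay, at which 3 of the 3 values shown sit. For the measured compounds named here, the one measured step, a step that the two limits leave unreadable from compound 1 to compound 2, has both ends at a limit and so gives no readable size.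

Compound 4 `Cc1ccc2[nH]c(=O)c(-c3nc4cc(F)ccc4[nH]3)cc2c1` differs from compound 1 by fluoro in place of nitro on an aromatic carbon. Going by the values given here, no measured step bears on this change. With every value shown sitting at the limit, the expected step is a step that the limit leaves unreadable from compound 1 to compound 4, none beyond the scatter. Compound 4 is estimated at 150000 nM, between 50000 nM and 500000 nM, most likely again reported as a limit.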

Compound 4, half-maximal inhibitory concentration: > 100000 nM
Compound 4 was reported as a limit (the forecaster's own chance of this, stated with the estimate: 85%); the middle value lies beyond the limit too.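

Compound 1 and compound 4 are both reported as limits of the assay, so no step between them can be read: the limit of > 100000 nM in this assay, at which 4 of the 4 values shown sit.

The compounds shown leave open how far each lies beyond that limit, and whether fluoro in place of nitro changes cytotoxicity at all.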